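Capping the Amine of a Long-Chain Amino Ether

The source may hold more compounds than are shown below. What is called first, only, known or untested is meant among the compounds shown, and "the series" means these compounds.

Compound 1 `CCCCCCCCCCCCCCC(N)COCc1ccccc1` carries a free amine on a long saturated chain together with a benzyl ether. Going by the values given here, in a functional assay on Jurkat cells (Homo sapiens) for inhibition (on this read-out higher numbers stand for weaker inhibition and lower numbers for stronger inhibition), compound 1 gives 3000 nM, one of only two plain numbers recorded here. Compound 2 `CCCCCCCCCCCCCCC(CO)NCCCCCC`, which has a hydroxymethyl group in place of the benzyl ether and a hexyl chain on the amine, gives 6000 nM, a value within the scatter of that of compound 1, so the two cannot be ranked. Compound 3 `CCCCCCCCCCCCCCC(COCc1ccccc1)NC(=O)CCCC(=O)O` is compound 1 with the amine hydrogen replaced by a (3-carboxypropyl)carbonyl group, and for compound 3 the assay reports only a limit, > 50000 nM. Among the compounds with values here, the step of an at least 16-fold higher number from compound 1 to compound 3 (1.22 log units; beyond the scatter) is the single measured change that speaks to the question at hand. That one of the three values sits at this limit of > 50000 nM in this assay, at which 1 of the 3 values shown sits, means the true size of that step is known only as a lower bound.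

Compound 4 `CCCCCCCCCCCCCCC(COCc1ccccc1)NC(=O)CCC(=O)O` differs from compound 1 in one place: (2-carboxyethyl)carbonyl in place of hydrogen on an amine nitrogen. This is the same kind of capping of the amine as in compound 3, with a shorter diacid chain. Because the step of an at least 16-fold higher number from compound 1 to compound 3 (1.22 log units; beyond the scatter) was large, a rise of similar size is expected for a 20-fold higher number from compound 1 to compound 4 (1.30 log units; beyond the scatter). Compound 4 is accordingly estimated at 60000 nM, most likely between 15000 nM and 250000 nM, and the assay may once more report only a limit.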

Compound 4, half-maximal inhibitory concentration: 30000 nM
Beside the measured number, compound 4's estimate is 2.0-fold (0.30 log units) above it, and the stated range covers the measured number.
By their numbers in this assay, from the lowest: compounds 1 and 2 (each within the scatter of the next); then compound 4. At a limit, above all of these: compound 3.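

Capping the amine now has a measured size in this assay: the step is a 10-fold higher number from compound 1 to compound 4 (1.00 log units; beyond the scatter), and it is a plain number rather than a lower bound. It shows that a compound with a diacid cap on this amine nitrogen can still give a readable value in this assay, so the cap weakens inhibition without necessarily taking it past what the assay can report. The change in the length of the cap reads as an at least 1.6-fold lower number from compound 3 to compound 4 (0.22 log units; that floor lies within the scatter), and the two caps cannot be ranked, because the value for compound 3 is a limit and not a number: the limit of > 50000 nM in this assay, at which 1 of the 4 values shown sits.

The compounds shown leave open whether the rise goes with the amide link itself or with the free carboxylic acid at the end of the cap, and an acetyl group on the same amine nitrogen, or a methyl ester in place of that acid, would tell the two apart. Compound 2 differs from compound 1 in more than one place, so the separate contributions of the benzyl ether and of the hexyl chain on the amine also remain unsettled.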